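Swapping the Phenyl Group on a Shared Core

The source may report more compounds than this note shows. Statements on the series, on what has been measured and on what is new or still open speak of the compounds shown alone.

In a functional assay on MCF7 cells (Homo sapiens) for antiproliferative activity, read by MTT assay, with a stated time of 48 h (a lower number here means a stronger inhibitor, a higher number a weaker inhibitor), compound 3 `N#CC1=C(N)Oc2c(N)cc3nc4ccccc4nc3c2C12C(=O)N(Cc1cnnn1-c1ccccc1Cl)c1ccccc12` gives 34400 nM, the lowest of the two plain numbers recorded. Compound 2 `N#CC1=C(N)Oc2c(c3nc4ccccc4nc3c3ccccc23)C12C(=O)N(Cc1cnnn1-c1ccc(Br)cc1)c1ccccc12` gives 36600 nM, which sits within the scatter of compound 3. Compound 1 `Cc1cccc(-n2nncc2CN2C(=O)C3(C(C#N)=C(N)Oc4c3c3nc5ccccc5nc3c3ccccc43)c3ccccc32)c1` reaches only a limit of this assay, > 50000 nM. Compound 4 `Cc1ccc(Cl)cc1-n1nncc1CN1C(=O)C2(C(C#N)=C(N)Oc3c(N)cc4nc5ccccc5nc4c32)c2ccccc21` is yet to be measured; it differs from compound 3 by 5-chloro-2-methylphenyl in place of 2-chlorophenyl on an aromatic nitrogen. Within the data shown here, the single measured step, an at least 1.3-fold lower number from compound 1 to compound 2 (0.13 log units; that floor lies within the scatter), also exchanges the group on that aromatic nitrogen, and its floor lies within the scatter, so it offers no clear direction. A step of a 1.0-fold higher number from compound 3 to compound 4 (0.01 log units; within the scatter) of no more than the scatter is expected. Compound 4 is therefore estimated at 35000 nM, with a range from 15000 nM to 80000 nM.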

Compound 4, half-maximal inhibitory concentration: 43500 nM
The estimate for compound 4 lay 1.2-fold (0.09 log units) below the measured number, and the stated range covers the measured number.
By their numbers in this assay, from the lowest: compounds 3, 2 and 4 (each within the scatter of the next). At a limit, above all of these: compound 1.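

In this assay, among these compounds, the first step at this aromatic nitrogen with a plain number at both ends is a 1.3-fold higher number from compound 3 to compound 4 (0.10 log units; within the scatter). On the core of compound 3, then, exchanging 2-chlorophenyl for 5-chloro-2-methylphenyl leaves the number unchanged within the scatter, which the step to compound 2, starting from a limit, could not show. Little room remains above these numbers: the limit of > 50000 nM in this assay, at which 1 of the 4 values shown sits.

Every group shown at this position is a substituted phenyl. From the compounds shown here alone, whether a longer alkyl chain, or a phenyl carrying an amine or a carboxylic acid, would lower the number stays open.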